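Lengthening the chloroalkyl chain on the amide

The compounds below may be only part of what the source reports. "The series", "measured", "known", "first", "only" and "open" are said of these compounds alone.

Measured so far:
compound 1 `COc1ccccc1C(=O)Nc1nnc(SCC(=O)Nc2ccc(Cl)cn2)s1`: > 80000 nM
compound 2 `O=C(CSc1nnc(NC(=O)CCl)s1)Nc1ccc(Cl)cn1`: 8600 nM

In a functional assay on A875 cells (Homo sapiens) for antiproliferative activity, read by MTT assay, with a stated time of 48 h (a higher number here means a weaker inhibitor, a lower number a stronger inhibitor), compound 2 gives 8600 nM, the only number shown. Compound 1 reaches only a limit of the assay at > 80000 nM (the limit of > 80000 nM in this assay, at which 1 of the 2 values shown sits). Among the compounds with values here, the single measured step is an at least 9.3-fold lower number from compound 1 to compound 2 (0.96 log units; beyond the scatter). Compound 3 `O=C(CSc1nnc(NC(=O)CCCCl)s1)Nc1ccc(Cl)cn1` differs from compound 2 by 2-chloroethyl in place of chloro on a saturated chain carbon bound to a carbonyl carbon. Within the data shown here, no measured step touches this kind of chain extension, so the prediction rests on compound 2 alone. Compound 3 is expected to stay close to compound 2, with an estimated step of a 1.2-fold higher number from compound 2 to compound 3 (0.07 log units; within the scatter) in this assay. The estimate for compound 3 is 10000 nM, ranging from 3000 nM to 40000 nM.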

Compound 3, half-maximal inhibitory concentration: > 80000 nM
Compound 3: no number, only a limit; the forecaster's own chance of this, stated with the estimate: 15%; middle value at least 8.0-fold (0.90 log units) away from the limit.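

In this assay, this position on the carbonyl carbon proves sensitive to chain length: going from chloromethyl to 3-chloropropyl gives an at least 9.3-fold higher number from compound 2 to compound 3 (0.96 log units; beyond the scatter), so the terminal chlorine alone does not secure activity. Compound 3 gives only a limit of the assay: the limit of > 80000 nM in this assay, at which 2 of the 3 values shown sit. The step from compound 1 to compound 3 joins two limits and cannot be read.

As far as these compounds go, whether 2-chloroethyl on the carbonyl carbon would keep any activity stays open. So does the effect of an amine in place of the chlorine.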